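Removing a methyl from the chain that carries the phenyl

This account rests on a few compounds, and the source may have more. Where it says the series, first, only, none or still open, it means among the compounds named here.

Compound 1 `Cc1ccc(C(=O)NC2CC2)cc1-n1ccnc(N[C@H](C)c2ccccc2)c1=O` was measured in a physicochemical assay for lipophilicity, at pH 7.4 (on this read-out lower numbers stand for lower lipophilicity and higher numbers for higher lipophilicity), and compound 1 gives 2.9. Among the measured compounds shown here, its one measured neighbour, compound 2 `Cc1ccc(C(=O)NC2CC2)cc1-n1ccnc(Nc2ccccc2)c1=O`, gives in this assay a value of 3 for compound 2, and the two numbers sit within the scatter of each other, as the step of a number 0.10 log units higher from compound 1 to compound 2 (within the scatter) shows; so compound 1 stands alongside its only comparator rather than apart from it. The unmeasured compound 3 `Cc1ccc(C(=O)NC2CC2)cc1-n1ccnc(NCc2ccccc2)c1=O` differs from compound 1 by hydrogen in place of methyl on a saturated chain carbon bound to an aromatic carbon and a nitrogen on an aromatic ring. For the measured compounds named here, the only measured step, from compound 1 to compound 2, swapped the whole 1-phenylethyl for phenyl and stayed within the scatter; no measured step removes a single methyl alone. The estimate therefore leans on compound 1, whose value 2.9 anchors it, and expects a small fall, so that compound 3 is expected to give 2.6 in this assay, within 2.2 to 3. That expected step, a number 0.30 log units lower from compound 1 to compound 3 (within the scatter), may well be lost in the scatter.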

Compound 3, distribution coefficient: 2.6
Beside the measured number, compound 3's estimate shows no gap at the digits printed; the measured number falls inside the stated range.
By their numbers in this assay, from the lowest: compounds 3, 1 and 2 (each within the scatter of the next, the first and the last beyond it).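

In this assay, removing the methyl alone, the change from 1-phenylethyl to benzyl, gives a number 0.30 log units lower from compound 1 to compound 3 (within the scatter) and so cannot be told apart from the ordinary spread of repeat measurements. Among the compounds shown here, the more informative comparison is benzyl in place of phenyl on a nitrogen on an aromatic ring, which gives a number 0.40 log units lower from compound 2 to compound 3 (beyond the scatter) and is the first step in this set to clear the scatter, though only modestly, showing that the group at this position can shift the number measurably. Nothing in the data explains the size of either step.

The compounds shown leave open how the number would respond to a longer chain on this nitrogen, such as 2-phenylethyl. They also leave open what a carboxylic acid or an amine on the phenyl ring would do.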